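This account rests on a few compounds, and the source may have more. Where it says the series, first, only, none or still open, it means among the compounds named here.

The series shares one core, seen in compound 1 `COc1cccc(/C=C/C(=O)Nc2cc(OC)c(OC)c(OC)c2)c1`, in compound 2 `COc1ccc(/C=C/C(=O)Nc2cc(C(=O)c3cc(OC)c(OC)c(OC)c3)ccc2OC)cc1` and in compound 3 `COc1ccc(C(=O)c2cc(OC)c(OC)c(OC)c2)cc1NC(=O)/C=C/c1ccc(F)cc1`. In a functional assay on HT-29 cells (Homo sapiens) for cytotoxicity, read by MTT assay, with a stated time of 72 h (on this read-out higher numbers stand for weaker inhibition and lower numbers for stronger inhibition), compound 1 gives 2400 nM, compound 2 gives 5010 nM and compound 3 gives 1800 nM. Compound 3 carries the lowest of the three numbers, but its gap to compound 1 lies within the scatter, so no order between those two can be read; only compound 2 stands apart, through a 2.8-fold lower number from compound 2 to compound 3 (0.44 log units; beyond the scatter).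

Compound 4 `COc1ccc(C(=O)c2cc(OC)c(OC)c(OC)c2)cc1NC(=O)/C=C/c1ccc(N)cc1` is not yet measured. The change from compound 3 is amino in place of fluoro on an aromatic carbon, on an aromatic carbon of a six-membered aromatic ring of carbon only, para to a large group. Going by the values given here, no measured pair sets fluoro against amino. Among the compounds with values here, the one step at this position is a 2.8-fold lower number from compound 2 to compound 3 (0.44 log units; beyond the scatter), methoxy to fluoro; it shows that this position can move the number by a modest amount, but gives no direction for an amino, which carries a donor and an acceptor where the fluoro carried none. The expectation for compound 4 is therefore a step of a 1.7-fold higher number from compound 3 to compound 4 (0.22 log units; within the scatter) that may run either way, centred near no change and given a wide range. Compound 4 is estimated at 3000 nM, between 1000 nM and 9000 nM.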

Compound 4, half-maximal inhibitory concentration: 5600 nM
Compound 4: middle estimate off by 1.9-fold (0.27 log units), on the low side; low and high end bracket the measured number.
By their numbers in this assay, from the lowest: compounds 3 and 1 (each within the scatter of the next); then compounds 2 and 4 (each within the scatter of the next).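

In this assay, going by these compounds alone, the direct comparison of fluoro with amino on this aromatic carbon, para to a large group, gives a 3.1-fold higher number from compound 3 to compound 4 (0.49 log units; beyond the scatter) and places the amino on the higher side of the fluoro, a direction the earlier compounds could not supply. Amino and methoxy cannot be told apart at this position, with a 1.1-fold higher number from compound 2 to compound 4 (0.05 log units; within the scatter) as the step between them, so among the three groups shown only the fluoro of compound 3 stands apart, and the two steps away from it are of similar modest size. No evidence is available on why the fluoro separates from the other two groups.

On these data alone, whether the lower number belongs to fluoro alone remains open: a chloro, a trifluoromethyl, a nitrile or a hydroxyl on the same carbon could fall with the fluoro or with the amino and methoxy. Also open, as far as these compounds go, is whether the step from 4-fluorophenyl to 4-aminophenyl would keep its direction and size on a different core or in another cell line.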